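This account rests on a few compounds, and the source may have more. Where it says the series, first, only, none or still open, it means among the compounds named here.

Series notes on maximal response in an assay on isolated protein for agonist activity at Bile acid receptor (Homo sapiens), read by FRET; on this read-out lower numbers stand for smaller maximal responses and higher numbers for larger maximal responses:

compound 1 `CC(C)c1onc(-c2c(Cl)cccc2Cl)c1COc1ccc(N(C)Cc2ccc(OCCO)cc2)c(C(F)(F)F)n1` — 87%
compound 2 `CC(C)c1onc(-c2c(Cl)cccc2Cl)c1COc1ccc(N(C)Cc2cccc(C(=O)NS(C)(=O)=O)c2)c(C(F)(F)F)n1` — 110%
compound 3 `CC(Nc1ccc(C(=O)O)cc1)c1ccc(OCc2c(-c3c(Cl)cccc3Cl)noc2C2CC2)nc1C(F)(F)F` — 99%

Compound 3 stands second highest of the three numbers. Its nearest neighbour is compound 2, whose value lies higher by a margin beyond the usual scatter; furthest away is compound 1, lower, again beyond the scatter. Within the data shown here, no pair of measured compounds differs in a single place, so the three values show only that all of them reach a similar broad region of maximal response in this assay, without a single-change step to lean on.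

Compound 4 `CC(Oc1ccc(C(=O)O)cc1)c1ccc(OCc2c(-c3c(Cl)cccc3Cl)noc2C2CC2)nc1C(F)(F)F` is the next compound to be measured in this assay. It differs from compound 3 in one place: 4-carboxyphenoxy in place of (4-carboxyphenyl)amino on a saturated chain carbon bound to an aromatic carbon and a saturated chain carbon The rest of the molecule is unchanged. Among the measured compounds shown here, no measured step of this kind exists in the set, so the expectation rests on the narrow spread of the three numbers around compound 3. The expected step is a number 4 percentage points lower from compound 3 to compound 4 (within the scatter), small and likely within the scatter. Compound 4 is estimated at 95%, with a range from 75% to 115%.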

Compound 4, largest response reached (reported as efficacy), in percent of the reference or control that the assay uses: 89%
Estimate against measurement, compound 4: 6 percentage points above; measured number inside the range.
By their numbers in this assay, from the lowest: compounds 1, 4 and 3 (each within the scatter of the next, the first and the last beyond it); then compound 2.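

In this assay, the change at this position now has its first single-change step in the series: putting 4-carboxyphenoxy in place of (4-carboxyphenyl)amino on a saturated chain carbon bound to an aromatic carbon and a saturated chain carbon gives a number 10 percentage points lower from compound 3 to compound 4 (within the scatter), so the two groups cannot be told apart on this read-out. Among these compounds, the nitrogen of the leaving group can therefore give way to an oxygen, with fewer hydrogen-bond donors in the entering group, and the maximal response stays within the scatter, something the earlier compounds, none of them a single change from another, could not show. No measurement of any property of these two groups accompanies the step.

On these data alone, whether a sulfur atom or a methylene link at the same place would also keep the response in this region stays open, as does the part played by the carboxylic acid, which a tetrazole or an acylsulfonamide on the same ring would test. Compounds 1 and 2 also remain unconnected to this pair by any single change, so the isopropyl and cyclopropyl groups on the shared core cannot be compared.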